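Carbonyl to Sulfonyl on the Ring Nitrogen

The source may report more compounds than this note shows. Statements on the series, on what has been measured and on what is new or still open speak of the compounds shown alone.

Measured compounds:
compound 1, `O=C(Nc1cccc(/C=C/C(=O)c2nc3ccccc3[nH]2)c1)c1cccc(Cl)c1`: 7840 nM
compound 2, `O=C(Nc1cccc(/C=C/C(=O)c2nc3ccccc3[nH]2)c1)c1cc(Cl)cc(Cl)c1`: > 100000 nM
compound 3, `O=C(/C=C/c1cccc(NS(=O)(=O)c2cccc(Cl)c2)c1)c1nc2ccccc2[nH]1`: 4160 nM

In a functional assay on MCF7 cells (Homo sapiens) for antiproliferative activity, read by MTT assay, with a stated time of 48 h (on this read-out lower numbers stand for stronger inhibition and higher numbers for weaker inhibition), compound 1 gives 7840 nM, the highest of the two numbers that were obtained; its nearest neighbour is compound 3, which gives 4160 nM, and the gap a 1.9-fold lower number from compound 1 to compound 3 (0.28 log units; within the scatter) lies within the scatter. For compound 2 the assay reports only a limit, > 100000 nM, which is the limit of > 100000 nM in this assay, at which 1 of the 3 values shown sits. The step of an at least 12-fold higher number from compound 1 to compound 2 (1.10 log units; beyond the scatter) is large, as is the step of an at least 24-fold lower number from compound 2 to compound 3 (1.38 log units; beyond the scatter).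

Compound 4, `O=C(/C=C/c1cccc(NS(=O)(=O)c2ccc(Cl)cc2)c1)c1nc2ccccc2[nH]1`, has not yet been measured. It differs from compound 1 as follows: (4-chlorophenyl)sulfonyl in place of (3-chlorophenyl)carbonyl on a nitrogen on an aromatic ring. Within the data shown here, the one measured step that bears on this change is the move to compound 3, where a (3-chlorophenyl)sulfonyl replaced a (3-chlorophenyl)carbonyl on the same nitrogen and gave a 1.9-fold lower number from compound 1 to compound 3 (0.28 log units; within the scatter), a change within the scatter. Among the measured compounds shown here, no measured pair shows the shift of the chloro from the 3-position to the 4-position of that phenyl, so this part of the change is untested. On this basis no step beyond the scatter is expected for compound 4, that is a 1.4-fold lower number from compound 1 to compound 4 (0.15 log units; within the scatter). Compound 4 is expected to give about 5500 nM, estimated to lie between 1500 nM and 20000 nM.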

Compound 4, half-maximal inhibitory concentration: 3820 nM
Compound 4: the middle estimate sits 1.4-fold (0.16 log units) above what was measured; the measured number falls inside the stated range.
By their numbers in this assay, from the lowest: compounds 4, 3 and 1 (each within the scatter of the next, the first and the last beyond it). At a limit, above all of these: compound 2.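

In this assay, 4-chlorophenyl in place of 3-chlorophenyl on a sulfonyl sulfur gives a 1.1-fold lower number from compound 3 to compound 4 (0.04 log units; within the scatter), so this first test of where the chloro sits on that ring shows no change beyond the scatter, and the two sulfonyl compounds cannot be ranked. Going from the carbonyl to the sulfonyl series, with the chloro moved as well, gives a 2.1-fold lower number from compound 1 to compound 4 (0.31 log units; beyond the scatter): this modest step lies just beyond the scatter, whereas the earlier swap that kept the 3-chlorophenyl stayed within it. The step of an at least 26-fold lower number from compound 2 to compound 4 (1.41 log units; beyond the scatter) is large, but it starts from a value that is a limit of the assay and not a number: the limit of > 100000 nM in this assay, at which 1 of the 4 values shown sits.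

Going by these compounds, it remains open whether the chloro matters at all on the sulfonyl side, or whether a methoxy group or an amine in its place on that phenyl ring would give similar numbers. Also open, on these data alone, is whether a 3,5-dichlorophenyl on the sulfonyl would lose activity in the way the 3,5-dichlorophenyl on the carbonyl of compound 2 did.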